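Anilino swap on the bromophenyl core

A few compounds are considered here, and "the series" means these few. Any claim that something is new, unique, unknown or untested is made for them only; others in the source may bear on it.

Measured so far in a functional assay on ECa-109 cells (Homo sapiens) for inhibition, read by MTT assay, with a stated time of 72 h; a higher number here means a weaker inhibitor, a lower number a stronger inhibitor:
Compound 1 `COc1cc(-c2nc(SCc3cn(CC(=O)NC(=O)Nc4ccccn4)nn3)nc(Nc3cccc(C(F)(F)F)c3)c2C#N)cc(OC)c1OC` — compound 1 reaches only a limit of this assay, > 64000 nM.
Compound 2 `Cc1ccc(-c2nc(SCc3cn(CC(=O)NC(=O)Nc4ccccn4)nn3)nc(Nc3cccc(C(F)(F)F)c3)c2C#N)cc1` — compound 2 gives 32300 nM.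
Compound 3 `Cc1ccc(Nc2nc(SCc3cn(CC(=O)NC(=O)Nc4ccccn4)nn3)nc(-c3ccc(Br)cc3)c2C#N)cc1` — compound 3 gives 7920 nM.

Compound 3 holds the lowest of the two numbers; compound 2 sits higher, beyond the scatter, and compound 1 stands at the limit of > 64000 nM in this assay, at which 1 of the 3 values shown sits. Compound 4 is `N#Cc1c(Nc2cccc(C(F)(F)F)c2)nc(SCc2cn(CC(=O)NC(=O)Nc3ccccn3)nn2)nc1-c1ccc(Br)cc1`; the change from compound 3 is 3-(trifluoromethyl)phenyl in place of 4-methylphenyl on a nitrogen on an aromatic ring. Going by the values given here, the only measured step, an at least 1.9-fold lower number from compound 1 to compound 2 (0.29 log units; that floor lies within the scatter), alters the aryl on carbon, not the anilino group, so it does not bear on this change. Compounds 1 and 2 both carry (3-(trifluoromethyl)phenyl)amino and both give higher numbers than compound 3, yet they also differ in the other aryl. A moderate rise, a 1.9-fold higher number from compound 3 to compound 4 (0.28 log units; within the scatter), is therefore expected. Compound 4 is estimated at 15000 nM, in the range 5000 nM to 45000 nM.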

Compound 4, half-maximal inhibitory concentration: 2960 nM
For compound 4 the middle estimate is 5.1-fold (0.70 log units) above the measured one; the whole stated range lies above it.
By their numbers in this assay, from the lowest: compound 4; then compound 3; then compound 2. At a limit, above all of these: compound 1.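

The first step read on the nitrogen is a 2.7-fold lower number from compound 3 to compound 4 (0.43 log units; beyond the scatter): with the 4-bromophenyl held, (3-(trifluoromethyl)phenyl)amino replaces (4-methylphenyl)amino. With (3-(trifluoromethyl)phenyl)amino held, two large steps come from the aryl on carbon: bromo in place of methyl gives an 11-fold lower number from compound 2 to compound 4 (1.04 log units; beyond the scatter), and 4-bromophenyl in place of 3,4,5-trimethoxyphenyl gives an at least 21-fold lower number from compound 1 to compound 4 (1.33 log units; beyond the scatter). Compound 1 gives a limit, not a number, so that last step is only a floor: the limit of > 64000 nM in this assay, at which 1 of the 4 values shown sits.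

Going by these compounds, whether the nitrogen step holds with 4-methylphenyl or 3,4,5-trimethoxyphenyl on carbon stays open. So does the outcome with a cyclohexylamine or a morpholine in place of the aryl amine.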